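Swapping the benzyl ether aryl group in an EP1 series

The source may report more compounds than this note shows. Statements on the series, on what has been measured and on what is new or still open speak of the compounds shown alone.

Of the compounds shown here, three have been measured in an assay on CHO-K1 cells for displacement of a labelled ligand from prostaglandin E2 receptor EP1 subtype (Homo sapiens); on this read-out higher numbers stand for weaker inhibition and lower numbers for stronger inhibition. Compound 1 `O=C(O)c1ccn(Cc2cc(Br)ccc2OCc2ccccc2)n1` gives 9.77 nM. For the measured compounds named here, compound 2 `Cc1cn(Cc2cc(Br)ccc2OCc2ccccc2)nc1C(=O)O`, which carries a methyl group on an aromatic carbon of the shared core, gives 427 nM; the single one-point step here, a 44-fold higher number from compound 1 to compound 2 (1.64 log units; beyond the scatter), is a large loss. Compound 3 `Cc1cc(C(=O)O)nn1Cc1cc(Br)ccc1OCc1ccc(F)cc1F` gives 0.525 nM, the lowest number of the three and beyond the scatter from both others, so it is the most potent compound measured.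

Compound 4 `Cc1cccc(COc2ccc(Br)cc2Cn2nc(C(=O)O)cc2C)c1` differs from compound 3 in one place: 3-methylphenyl in place of 2,4-difluorophenyl on a saturated chain carbon bound to an oxygen on an aromatic ring. Going by the values given here, none of the measured steps touches this part of the molecule; the only one-point step concerns a methyl on the core, and compound 1 differs from compound 3 in two places at once, so their values alone show that the difluorinated ether sits on the stronger side. Among the compounds with values here, with no direct precedent, the expectation for compound 4 is a modest weakening, a 2.9-fold higher number from compound 3 to compound 4 (0.46 log units; beyond the scatter), and compound 4 is estimated at 1.5 nM, within a range from 0.4 nM to 6 nM.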

Compound 4, half-maximal inhibitory concentration: 126 nM
Compound 4: the middle estimate sits 84-fold (1.92 log units) below what was measured; measured number outside the range, above it.
By their numbers in this assay, from the lowest: compound 3; then compound 1; then compound 4; then compound 2.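

For the compounds shown here, this is the first one-place change read at this position: in this assay, 3-methylphenyl in place of 2,4-difluorophenyl gives a 240-fold higher number from compound 3 to compound 4 (2.38 log units; beyond the scatter), a large loss. The leaving and entering groups are each one six-membered aromatic ring of carbon only, with no net charge, so the substituents on that ring alone separate compound 3 from compound 4, and this position proves highly sensitive to them. Nothing measured here accounts for the size of this loss.

The step removes both fluorines and adds a methyl at once, so it leaves open whether the loss follows the departure of the fluorines, the arrival of the methyl, or the two together. Placing an unsubstituted phenyl, a 4-fluorophenyl or a 4-methylphenyl group on the same carbon of compound 3 would begin to separate these possibilities.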